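The source may hold more compounds than are shown below. What is called first, only, known or untested is meant among the compounds shown, and "the series" means these compounds.

Working notes on the series. Compound 1 `COc1ccc(CNc2nc([Se]C)nc3ccccc23)cc1` carries a methylselanyl group on the shared core, and compound 2 `COc1ccc(CNc2nc(SC)nc3ccccc23)cc1` carries a methylsulfanyl group in its place. In a functional assay on CCRF-CEM cells (Homo sapiens) for cytotoxicity, read by MTT assay, with a stated time of 72 h (a lower number here means a stronger inhibitor of growth, a higher number a weaker inhibitor of growth), compound 1 gives a limit of the assay, > 100000 nM. In this assay compound 2 also gives a limit of the assay, > 100000 nM. The step that the two limits leave unreadable from compound 1 to compound 2 is therefore not readable in size or direction. Compound 2 thus stands at the edge of what this assay can report, with no number of its own; both recorded values fall at the limit of > 100000 nM in this assay, at which 2 of the 2 values shown sit.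

Compound 3 `COc1ccc(CNc2nc(S)nc3ccccc23)cc1` differs from compound 2 by hydrogen in place of methyl on a sulfur. Among the measured compounds shown here, the one measured step, a step that the two limits leave unreadable from compound 1 to compound 2, concerns the same position on the core but is hidden by the two limits, so it gives no size to carry over. For the measured compounds named here, no other measured step bears on the change. With compound 2 at the limit, the expected outcome for compound 3 in this assay is 100000 nM, within 30000 nM to 300000 nM, most likely again reported as a limit. The step of a number no higher from compound 2 to compound 3 (the limit leaves the size open) is accordingly expected to be unreadable rather than a measured shift.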

Compound 3, concentration for total growth inhibition: 41000 nM
For compound 3 the middle estimate is 2.4-fold (0.39 log units) above the measured one; the measured number falls inside the stated range.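

In this assay, the change from methylsulfanyl to sulfanyl gives a readable step at this position, an at least 2.4-fold lower number from compound 2 to compound 3 (0.38 log units; beyond the scatter), and this size is only a lower bound on the true step, since one end of it is a limit. The change from the methylselanyl group to sulfanyl reads the same way, an at least 2.4-fold lower number from compound 1 to compound 3 (0.38 log units; beyond the scatter), so a hydrogen on the sulfur, with no methyl there, brings the series into the range where this assay reports a number, and compound 3 gives 41000 nM. The two compounds that carry a methyl on the chalcogen atom stay out of that range, so the comparison rests on a single number against two limits: the limit of > 100000 nM in this assay, at which 2 of the 3 values shown sit.

From the compounds shown here alone, the true size of both steps remains open, and the step between the methylselanyl and methylsulfanyl groups cannot be read, so nothing separates selenium from sulfur here. Also open, going by these compounds, is how an amine or a hydroxyl group at this place, or a longer chain on the sulfur, would compare with the sulfanyl group of compound 3.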